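A few compounds are considered here, and "the series" means these few. Any claim that something is new, unique, unknown or untested is made for them only; others in the source may bear on it.

Values in a functional assay on FM3A cells (Mus musculus) for antiproliferative activity, read by cell counting, with a stated time of 2 days; a higher number here means a weaker inhibitor, a lower number a stronger inhibitor:
- compound 1 `COc1cc(C(=O)c2sc(N3CCCC3)nc2N)cc(OC)c1OC`: 180 nM
- compound 2 `COc1ccc(C(=O)c2sc(N3CCCC3)nc2N)cc1OC`: 112000 nM
- compound 3 `COc1ccc(C(=O)c2sc(N3CCCC3)nc2N)cc1`: not yet measured

Compound 2 holds the higher number of the two measured compounds, so it is the weaker inhibitor. Compound 3 has hydrogen in place of methoxy on an aromatic carbon, ortho to a methoxy group and meta to a large group: hydrogen in place of methoxy on an aromatic carbon.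

Going by the values given here, one measured step bears on this, the same kind of replacement: a 620-fold higher number from compound 1 to compound 2 (2.79 log units; beyond the scatter). That step is large and beyond the scatter. It points towards a higher number in this assay, but a single step sets no size for a second one. With compound 2 already at 112000 nM, a repeat of that size is not expected, only a small rise, likely within the scatter. The expected change is a 1.2-fold higher number from compound 2 to compound 3 (0.06 log units; within the scatter). For compound 3 the estimated value is 130000 nM, with an expected range of 40000 nM to 400000 nM.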

Compound 3, half-maximal inhibitory concentration: > 200000 nM
Compound 3: no number, only a limit; the forecaster's own chance of this, stated with the estimate: 35%; middle value at least 1.5-fold (0.18 log units) away from the limit.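

In this assay the result for compound 3 is a limit and not a number: the limit of > 200000 nM in this assay, at which 1 of the 3 values shown sits. Hydrogen in place of the methoxy ortho to a methoxy group and meta to a large group gives an at least 1.7-fold higher number from compound 2 to compound 3 (0.25 log units; that floor lies within the scatter), so this change can be read only as a floor, and that floor alone does not set the two compounds apart. Unlike a 620-fold higher number from compound 1 to compound 2 (2.79 log units; beyond the scatter), which has a measured size, this second replacement of methoxy by hydrogen has none, and any further weakening at this position cannot be followed in this assay.

On these data alone, how the two replacements compare in size stays open, since that needs a number in place of the limit. Also open, as far as these compounds go, is whether a hydroxy group, a fluorine atom or an ethoxy group at this position would differ from methoxy.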